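From a Carbonyl to a Sulfonyl on Compound 1

The compounds below may be only part of what the source reports. "The series", "measured", "known", "first", "only" and "open" are said of these compounds alone.

Among the compounds with values here, in a physicochemical assay for solubility (on this read-out higher numbers stand for higher solubility and lower numbers for lower solubility), compound 1 `O=C(c1ccccn1)N1CCC(NS(=O)(=O)c2cc(S(=O)(=O)c3ccccc3)ccc2C(F)(F)F)CC1` gives 100000 nM, the highest of the three numbers measured so far. Compound 2 `O=C(c1ccc(Cl)nc1)N1CCC(NS(=O)(=O)c2cc(S(=O)(=O)c3ccccc3)ccc2C(F)(F)F)CC1` gives 25000 nM, and compound 3 `O=C(O)c1cccc(S(=O)(=O)N2CCC(NS(=O)(=O)c3cc(S(=O)(=O)c4ccccc4)ccc3C(F)(F)F)CC2)c1` gives 12500 nM. Compound 4 `N#Cc1cccc(S(=O)(=O)N2CCC(NS(=O)(=O)c3cc(S(=O)(=O)c4ccccc4)ccc3C(F)(F)F)CC2)c1` has not been measured yet, and its change is this: (3-cyanophenyl)sulfonyl in place of (pyridin-2-yl)carbonyl on an amine nitrogen in a ring. The closest guide is an 8.0-fold lower number from compound 1 to compound 3 (0.90 log units; beyond the scatter), where (3-carboxyphenyl)sulfonyl enters at the same place. A second guide is a 4.0-fold lower number from compound 1 to compound 2 (0.60 log units; beyond the scatter), where only the group on the carbonyl changes. Both steps lie beyond the scatter and point downward, so a drop of similar size is expected in this assay. The expected step is an 8.0-fold lower number from compound 1 to compound 4 (0.90 log units; beyond the scatter). For compound 4, the estimated value is 12500 nM, within a range of 3000 nM to 50000 nM.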

Compound 4, solubility: 6300 nM
The estimate for compound 4 lay 2.0-fold (0.30 log units) above the measured number; measured number inside the range.
By their numbers in this assay, from the lowest: compounds 4, 3 and 2 (each within the scatter of the next, the first and the last beyond it); then compound 1.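

In this assay, a second sulfonyl group on the ring nitrogen also lowers the number (a 16-fold lower number from compound 1 to compound 4 (1.20 log units; beyond the scatter)), and the same holds against the chloropyridine amide (a 4.0-fold lower number from compound 2 to compound 4 (0.60 log units; beyond the scatter)). The drop seen for compound 3 therefore does not require its carboxy group, and cyano in its place leaves the two compounds within the scatter (a 2.0-fold lower number from compound 3 to compound 4 (0.30 log units; within the scatter)). No measurement shown here explains these numbers.

The drop could follow either the sulfonyl link or the carbon-only ring, since both change together. A (pyridin-2-yl)sulfonyl group or a (3-aminophenyl)sulfonyl group would help to separate the two.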